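Aryl replacement repeated on a second core

The source may hold more compounds than are shown below. What is called first, only, known or untested is meant among the compounds shown, and "the series" means these compounds.

The series is read in a functional assay on DU-145 cells (Homo sapiens) for inhibition, read by trypan blue exclusion, with a stated time of 96 h; on this read-out lower numbers stand for stronger inhibition of growth and higher numbers for weaker inhibition of growth. Compound 1 `Cc1cc(C)cc(/C=C(/SCc2ccc(F)cc2)C(=O)c2ccc(Br)cc2)c1` gives 10000 nM in this assay. Compound 2 `CN(C)c1ccc(/C=C(/SCc2ccc(F)cc2)C(=O)c2ccc(Br)cc2)cc1` gives 50000 nM in this assay. Compound 3 `CN(C)c1ccc(/C=C(/SCc2ccc(Cl)cc2)C(=O)c2ccc(Cl)cc2)cc1` reaches only a limit of this assay, > 100000 nM, which is the limit of > 100000 nM in this assay, at which 1 of the 3 values shown sits. How the core of compound 3 differs from that of compound 2 is not broken down here.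

Within the measured pair, the change 3,5-dimethylphenyl in place of 4-(dimethylamino)phenyl on a double-bonded chain carbon bound to a double-bonded chain carbon brings a 5.0-fold lower number from compound 2 to compound 1 (0.70 log units; beyond the scatter).

The same change, at a place described in the same words, is applied to compound 3 to give compound 4 `Cc1cc(C)cc(/C=C(/SCc2ccc(Cl)cc2)C(=O)c2ccc(Cl)cc2)c1`, which is not yet measured in this assay: 3,5-dimethylphenyl in place of 4-(dimethylamino)phenyl on a double-bonded chain carbon bound to a double-bonded chain carbon.

For the measured compounds named here, because compound 3 sits at a limit, the step from it cannot be anchored to a number; the measured step from compound 2 to compound 1 is the only guide, and the core of compound 3 has so far given no number at all. For compound 4 a step of about an at least 3.3-fold lower number from compound 3 to compound 4 (0.52 log units; beyond the scatter) is expected. Compound 4 is estimated at 30000 nM, between 10000 nM and 100000 nM.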

Compound 4, concentration for 50% growth inhibition: 10000 nM
The estimate for compound 4 lay 3.0-fold (0.48 log units) above the measured number; the range from low to high includes it.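

In this assay, replacing 4-(dimethylamino)phenyl with 3,5-dimethylphenyl gives an at least 10-fold lower number from compound 3 to compound 4 (1.00 log units; beyond the scatter), so the lower number seen with this change on the core of compound 2 recurs on the core of compound 3. Compound 3 stands at a limit of the assay, > 100000 nM, and this value is not a number. The direction of the change thus carries across these two pairs, but its full size on the second core stays unfixed and the two steps cannot be called equal or different: the same change on two cores in this assay, a 5.0-fold lower number (0.70 log units; beyond the scatter) from compound 2 to compound 1 and an at least 10-fold lower number (1.00 log units; beyond the scatter) from compound 3 to compound 4; the limit leaves it open whether they differ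

The compounds shown leave open whether the lower number needs the two methyl groups of 3,5-dimethylphenyl or would also appear with an unsubstituted phenyl or a methoxyphenyl group at the same place. They also leave open whether the change would carry to a further core, for example one with a nitrile in place of the halogens.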